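From an ethyl(methyl)amide to an azetidine amide

The compounds below may be only part of what the source reports. "The series", "measured", "known", "first", "only" and "open" are said of these compounds alone.

Measured in an assay on the whole organism (plasma, strain Sprague-Dawley) for inhibition of Dipeptidyl peptidase 4 (Rattus norvegicus), with a stated time of 6 h, at a dose of 1 mg/kg by the oral route; on this read-out higher numbers stand for more inhibition at the one dose given (going by the name of the read-out) and lower numbers for less inhibition: compound 1 `C=CC[C@@H]1CN[C@H](C(=O)N2CCC[C@H]2C#N)C1` gives 38%; compound 2 `CN(C)C(=O)C[C@@H]1CN[C@H](C(=O)N2CCC[C@H]2C#N)C1` gives 66%; compound 3 `CCN(C)C(=O)[C@@H]1CN[C@H](C(=O)N2CCC[C@H]2C#N)C1` gives 71%.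

Compound 3 holds the highest of the three numbers, but its lead over compound 2, a number 5 percentage points higher from compound 2 to compound 3 (within the scatter), lies within the scatter; only its distance from compound 1, a number 33 percentage points higher from compound 1 to compound 3 (beyond the scatter), is beyond it. Compound 4 `N#C[C@@H]1CCCN1C(=O)[C@@H]1C[C@H](C(=O)N2CCC2)CN1` differs from compound 3 in one place: azetidin-1-yl in place of ethyl(methyl)amino on a carbonyl carbon. The step that bears most directly on this change is a number 5 percentage points higher from compound 2 to compound 3 (within the scatter), a variation at the same carbamoyl group that stayed within the scatter. The larger steps of a number 28 percentage points higher from compound 1 to compound 2 (beyond the scatter) and a number 33 percentage points higher from compound 1 to compound 3 (beyond the scatter) concern the arrival of a carbamoyl group, which compound 4 keeps. No step beyond the scatter is therefore expected, and the estimated change is a number 3 percentage points lower from compound 3 to compound 4 (within the scatter). Compound 4 is estimated at 68%, expected to fall between 52% and 82%.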

Compound 4, a percentage reported as inhibition, in the whole organism at one dose (the size of the read-out at that dose, not a potency): 77%
Beside the measured number, compound 4's estimate is 9 percentage points below it; measured number inside the range.
By their numbers in this assay, from the lowest: compound 1; then compounds 2, 3 and 4 (each within the scatter of the next, the first and the last beyond it).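

Replacing ethyl(methyl)amino with azetidin-1-yl, a ring of the same heavy-atom count, keeps this assay within the scatter, a number 6 percentage points higher from compound 3 to compound 4 (within the scatter), so a ring is accepted on this carbonyl carbon. The (azetidin-1-yl)carbonyl group also stands clear of (dimethylcarbamoyl)methyl, a number 11 percentage points higher from compound 2 to compound 4 (beyond the scatter), which compound 3 did not, and of allyl, a number 39 percentage points higher from compound 1 to compound 4 (beyond the scatter). Nothing available explains these steps.

As far as these compounds go, it remains open whether a larger ring such as piperidin-1-yl, or a carboxylic acid in place of the amide, would keep this level at this carbonyl carbon.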